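A Second Chloro on a Weak Modulator of a Chloride Channel

A few compounds are considered here, and "the series" means these few. Any claim that something is new, unique, unknown or untested is made for them only; others in the source may bear on it.

Compound 1, `CSc1cccc(Nc2nc(-c3cccc(Cl)c3)cs2)c1`, is the starting point. Among the compounds with values here, in an assay on CFBE41o cells for positive allosteric modulation of Cystic fibrosis transmembrane conductance regulator variant F508del (Homo sapiens), with stated times of 30 min and 24 h (on this read-out lower numbers stand for an effect already at smaller amounts and higher numbers for an effect only at larger amounts of compound), compound 1 gives 53000 nM, the only number among the compounds measured here, so its standing can be stated only against itself. Within the data shown here, compound 2, `CSc1cccc(Nc2nc(-c3cccs3)cs2)c1`, carries a different ring on the shared core and in this assay compound 2 was reported as "not active" (no number reported), with no number attached; it shows only that a swap at this part of the molecule can remove the effect entirely. Compound 3, `CSc1cccc(Nc2nc(-c3ccc(Cl)c(Cl)c3)cs2)c1`, differs from compound 1 by chloro in place of hydrogen on an aromatic carbon. Among the measured compounds shown here, no measured pair here shows what such an added chloro does, so the size of the step is open. The step of a 1.8-fold lower number from compound 1 to compound 3 (0.25 log units; within the scatter) is expected to be modest and toward an effect at smaller amounts, near the edge of the scatter. For compound 3 the estimate in this assay is 30000 nM, with a range from 8000 nM to 100000 nM.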

Compound 3, half-maximal effective concentration: "not active" (no number reported)
Compound 3: no number reported; no gap can be computed for the estimate.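

Within the data shown here, compound 3 was reported as "not active" in this assay, without a number, so no step from compound 1 to compound 3 can be read. Nothing measured here explains this result. As far as these compounds go, how far an added chloro at this place shifts the effect remains open.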